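Chloro Out, Methyl In: Expecting Another Limit

The source may hold more compounds than are shown below. What is called first, only, known or untested is meant among the compounds shown, and "the series" means these compounds.

Compound 3 `Cc1nc(C)c(-c2nn(-c3ccc(F)cc3)cc2/C=C/C(=O)c2cc(Cl)cc(Cl)c2O)s1` is one of three close relatives tested in an ADME assay on PANC-1 cells (Homo sapiens) for inhibition, read by MTT assay; a higher number here means a weaker inhibitor of growth, a lower number a stronger inhibitor of growth. In this assay compound 3 reaches only the limit > 250 ug/mL, which is not a measured number. Compound 1 `Cc1nc(C)c(-c2nn(-c3ccc(F)cc3)cc2/C=C/C(=O)c2cc(Br)ccc2O)s1` likewise stops at the limit > 250 ug/mL. Compound 2 `Cc1nc(C)c(-c2nn(-c3ccc(F)cc3)cc2/C=C/C(=O)c2cc(Cl)ccc2O)s1` also stands at the limit > 250 ug/mL. Because all three values sit at the limit of > 250 ug/mL in this assay, at which 3 of the 3 values shown sit, the steps a step that the two limits leave unreadable from compound 1 to compound 2, a step that the two limits leave unreadable from compound 1 to compound 3 and a step that the two limits leave unreadable from compound 2 to compound 3 cannot be read in size. Compound 4 `Cc1nc(C)c(-c2nn(-c3ccc(F)cc3)cc2/C=C/C(=O)c2cc(Cl)c(C)cc2O)s1` alters the group on the carbonyl carbon: 5-chloro-2-hydroxy-4-methylphenyl in place of 3,5-dichloro-2-hydroxyphenyl on a carbonyl carbon. For the measured compounds named here, none of the measured steps shows a change on this ring moving the read-out off the limit, so compound 4 is expected to show the step of a number no higher from compound 3 to compound 4 (the limit leaves the size open), meaning nothing beyond the scatter. Compound 4 is therefore estimated at 250 ug/mL, within 100 ug/mL to 500 ug/mL, most likely once more only as a limit.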

Compound 4, concentration for 50% growth inhibition: > 250 ug/mL
Compound 4: no number, only a limit; the forecaster's own chance of this, stated with the estimate: 80%; the middle value sits exactly at the limit.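

In this assay compound 4 gives > 250 ug/mL, which is a limit and not a number, so its steps from compound 1, compound 2 and compound 3 cannot be read in size. The compounds shown leave open how strongly each inhibits growth, and whether any change on this ring moves the read-out off the shared limit: the limit of > 250 ug/mL in this assay, at which 4 of the 4 values shown sit.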